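This account rests on a few compounds, and the source may have more. Where it says the series, first, only, none or still open, it means among the compounds named here.

Working notes on the cytotoxicity series.

Compound 1 `N#Cc1cn(COC(CO)CO)c2ncnc(N)c12` carries a cyano group on the shared core; compound 2 `NC(=O)c1cn(COC(CO)CO)c2ncnc(N)c12` is its carbamoyl counterpart, and compound 3 `N#Cc1cn(C(CO)OC(CO)CO)c2ncnc(N)c12` keeps the cyano group on a side chain lengthened by one hydroxymethyl. Compound 4 `NC(=O)c1cn(C(CO)OC(CO)CO)c2ncnc(N)c12` joins the carbamoyl group to that longer chain and has not yet been measured.

In an ADME assay on HFF cells (Homo sapiens) for cytotoxicity (on this read-out lower numbers stand for stronger inhibition and higher numbers for weaker inhibition), compound 1 gives > 320000 nM, which is a limit of the assay and not a number. In this assay compound 2 gives > 320000 nM, again a limit. In this assay compound 3 gives > 100000 nM, also a limit.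

The change from compound 1 to compound 2 is carbamoyl in place of cyano on an aromatic carbon; it gives a step that the two limits leave unreadable from compound 1 to compound 2. The two cores differ by hydroxymethyl in place of hydrogen on a saturated chain carbon bound to an aromatic nitrogen and an oxygen on a saturated carbon, and that step is a step that the two limits leave unreadable from compound 1 to compound 3. Within the data shown here, every value so far rests at a limit, the limit of > 100000 nM in this assay, at which 1 of the 3 values shown sits, for one compound and the limit of > 320000 nM in this assay, at which 2 of the 3 values shown sit, for the other two.

Compound 4 differs from compound 3 by carbamoyl in place of cyano on an aromatic carbon. Around the place, the ring atom bears a group of 9 heavy atoms rather than a group of 7 heavy atoms, so this is the same kind of change as from compound 1 to compound 2, not the same change.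

From compound 3 to compound 4 the step is expected to be a step that the limit leaves unreadable from compound 3 to compound 4, since the same kind of change gave a step that the two limits leave unreadable from compound 1 to compound 2 and no shown value has left its limit. For compound 4 in this assay the estimate is 320000 nM, with a likely range from 100000 nM to 1000000 nM, and most probably another limit.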

Compound 4, half-maximal inhibitory concentration: > 100000 nM
Compound 4: only a limit was reported; the forecaster's own chance of this, stated with the estimate: 85%; the middle value lies beyond the limit too.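

In this assay compound 4 gives > 100000 nM, which is a limit of the assay and not a number. Among these compounds, no new step can therefore be read, either from compound 3 to compound 4 or from compound 2 to compound 4. The compounds shown leave open whether carbamoyl in place of cyano, or hydroxymethyl in place of hydrogen, shifts this read-out at all, since all four values remain limits.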